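Adding methoxy to compound 3

A few compounds are considered here, and "the series" means these few. Any claim that something is new, unique, unknown or untested is made for them only; others in the source may bear on it.

Compound 3 `c1ccc2c(C3CC(c4ccncc4)=NO3)c[nH]c2c1` gives only a limit in a functional assay on HEK293 cells (Homo sapiens) for inhibition, read by MTT assay, with a stated time of 48 h (a lower number here means a stronger inhibitor, a higher number a weaker inhibitor), > 100000 nM. Compound 1 `Cc1[nH]c2ccccc2c1C1CC(c2ccncc2)=NO1` also gives only a limit, > 100000 nM. The data therefore show (the limit of > 100000 nM in this assay, at which 2 of the 3 values shown sit), and compound 3 has no numerical position in the series.

Compound 4 `COc1ccc2[nH]cc(C3CC(c4ccncc4)=NO3)c2c1` follows from compound 3 by one change: methoxy in place of hydrogen on an aromatic carbon. For the measured compounds named here, the only measured single change, a step that the two limits leave unreadable from compound 1 to compound 3, gives no size to carry over, and it concerns a different place and group.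

Going by the values given here, compound 2 `COc1ccc2c(c1)c(C1CC(c3ccncc3)=NO1)cn2Cc1ccc(Cl)cc1` also bears the methoxy and is the only compound with a number, 14200 nM. It carries a further substituent that compound 4 lacks, so its value cannot be credited to the methoxy alone.

A modest move toward stronger inhibition in this assay is expected, though it may not emerge from the limit. The expected change is an at least 1.4-fold lower number from compound 3 to compound 4 (0.15 log units; that floor lies within the scatter), an estimate of low confidence. For compound 4 the estimated value is 70000 nM, with an expected range of 25000 nM to 150000 nM.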

Compound 4, half-maximal inhibitory concentration: > 100000 nM
Compound 4 ended at the assay's limit; the forecaster's own chance of this, stated with the estimate: 60%; at least 1.4-fold (0.15 log units) between middle value and limit.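

In this assay compound 4 gives > 100000 nM, a limit and not a number, so methoxy at this place on the six-membered aromatic ring does not by itself bring the series off the limit, and the steps that join two limits cannot be read. For the compounds shown here, the methoxy-bearing pair does give a readable step: taking 4-chlorobenzyl off the aromatic nitrogen leaves an at least 7.0-fold higher number from compound 2 to compound 4 (0.84 log units; beyond the scatter), so the only number goes with that group and not with the methoxy alone. Readings remain concentrated at one limit: the limit of > 100000 nM in this assay, at which 3 of the 4 values shown sit.

On these data alone, how far compound 3 and compound 4 lie beyond the limit stays open, and with it any separate contribution from the methoxy. Also open, as far as these compounds go, is whether unsubstituted benzyl or a plain methyl on the aromatic nitrogen would give a number.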